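A few compounds are considered here, and "the series" means these few. Any claim that something is new, unique, unknown or untested is made for them only; others in the source may bear on it.

Measured compounds:
compound 1, `CCc1ccc(C(=O)N2CCN(Cc3nc4ccccc4n3Cc3cccc(C)c3)CC2)cc1`, 67%
compound 2, `Cc1cccc(Cn2c(CN3CCN(C(=O)CC(C)C)CC3)nc3ccccc32)c1`, 71.4%

In an assay on isolated protein for inhibition of aldehyde dehydrogenase 1A1 (Homo sapiens), read by spectrophotometry, tested at 10 uM (on this read-out higher numbers stand for more inhibition at the one concentration tested (going by the name of the read-out) and lower numbers for less inhibition), compound 2 and compound 1 give numbers that cannot be told apart: the step of a number 4.4 percentage points higher from compound 1 to compound 2 (within the scatter) lies within the scatter of repeated measurements. Going by the values given here, compound 2 therefore stands at the top of the two numbers only in a formal sense, with compound 1 as its sole neighbour and nothing to separate them.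

Compound 3, `Cc1cccc(Cn2c(CN3CCN(C(=O)c4ccc(C#N)cc4)CC3)nc3ccccc32)c1`, has not yet been measured in this assay. It differs from compound 2 in one place: 4-cyanophenyl in place of isobutyl on a carbonyl carbon. Among the compounds with values here, the only measured step that bears on this position is the one from compound 1 to compound 2, which exchanged a six-membered aromatic ring on the carbonyl carbon for isobutyl and gave a number 4.4 percentage points higher from compound 1 to compound 2 (within the scatter), a shift within the scatter. The change to compound 3 returns a six-membered aromatic ring to that same carbonyl carbon, now bearing a nitrile. On this single precedent no step beyond the scatter is expected; compound 3 is estimated at 68%, between 50% and 85%. The expected step is thus a number 3.4 percentage points lower from compound 2 to compound 3 (within the scatter), that is, essentially none.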

Compound 3, a percentage reported as inhibition, at one concentration (the size of the read-out at that concentration, not a potency): 20.8%
Estimate against measurement, compound 3: 47.2 percentage points above, and the stated range ends above it.
By their numbers in this assay, from the lowest: compound 3; then compounds 1 and 2 (each within the scatter of the next).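

In this assay, the substituent on this carbonyl carbon turns out to matter far more than the earlier pair suggested: 4-cyanophenyl in place of isobutyl gives a number 50.6 percentage points lower from compound 2 to compound 3 (beyond the scatter). Compound 1 also carries a six-membered aromatic ring on that carbonyl carbon and stays within the scatter of compound 2, so the presence of the ring alone does not go with the loss, whereas cyano in place of ethyl on an aromatic carbon gives a number 46.2 percentage points lower from compound 1 to compound 3 (beyond the scatter). Nothing available explains why this one exchange carries such a large step.

The compounds shown leave open whether the loss is specific to the nitrile or would also appear with other groups in place of ethyl on that aromatic carbon, such as a methoxy group, a chlorine atom or an amine. They also leave open whether a longer chain in place of isobutyl on the carbonyl carbon would stay within the scatter of compound 2, and how any of these numbers at one concentration would relate to potency.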